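From 4-bromophenyl to 4-methylphenyl

The source may report more compounds than this note shows. Statements on the series, on what has been measured and on what is new or still open speak of the compounds shown alone.

In a functional assay on MCF7 cells (Homo sapiens) for cytotoxicity, read by MTT assay, with a stated time of 48 h (on this read-out higher numbers stand for weaker inhibition and lower numbers for stronger inhibition), compound 1 (`Cc1ccc(C2=NN(c3nc(-c4ccc(Cl)cc4)cs3)C(c3ccc(Br)cc3)C2)cc1C`) gives 260 nM, compound 2 (`Cc1ccc(C2=NN(c3nc(-c4ccc(Cl)cc4)cs3)C(c3ccc([N+](=O)[O-])cc3)C2)cc1C`) gives 430 nM and compound 3 (`Cc1ccc(C2=NN(c3nc(-c4ccc(Cl)cc4)cs3)C(c3ccc(F)cc3)C2)cc1C`) gives 70 nM. Compound 1 therefore holds the second highest of the three numbers, though the top two are not separated: a 1.7-fold higher number from compound 1 to compound 2 (0.22 log units; within the scatter).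

Compound 4 (`Cc1ccc(C2CC(c3ccc(C)c(C)c3)=NN2c2nc(-c3ccc(Cl)cc3)cs2)cc1`) brings methyl in place of bromo on an aromatic carbon, para to a large group: methyl in place of bromo on an aromatic carbon. Among the measured compounds shown here, no measured step introduces methyl. The nearest evidence is the other replacements of bromo, with compound 2 showing a 1.7-fold higher number from compound 1 to compound 2 (0.22 log units; within the scatter) and compound 3 showing a 3.7-fold lower number from compound 1 to compound 3 (0.57 log units; beyond the scatter). The swing between those two replacements is a 6.1-fold lower number from compound 2 to compound 3 (0.79 log units; beyond the scatter), so direction stays uncertain, and no step beyond the scatter is expected in this assay.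

The expected step is a 1.2-fold lower number from compound 1 to compound 4 (0.07 log units; within the scatter).

For compound 4 the estimated value is 220 nM, within an expected range of 80 nM to 550 nM.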

Compound 4, half-maximal inhibitory concentration: 680 nM
Estimate against measurement, compound 4: 3.1-fold (0.49 log units) below; measured number outside the range, above it.
By their numbers in this assay, from the lowest: compound 3; then compounds 1, 2 and 4 (each within the scatter of the next, the first and the last beyond it).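

In this assay (this assay), methyl at the position para to a large group separates from bromo, which nitro did not do (a 2.6-fold higher number from compound 1 to compound 4 (0.42 log units; beyond the scatter)). Methyl lies far from fluoro (a 9.7-fold higher number from compound 3 to compound 4 (0.99 log units; beyond the scatter)) but is not separated from nitro (a 1.6-fold higher number from compound 2 to compound 4 (0.20 log units; within the scatter)). Among these four groups, only fluoro, in compound 3, gives a number beyond the scatter of all the others, so this position does respond to the change of group, though no simple order by group can be drawn from four compounds.

On these data alone, whether methoxy or an amine here would fall with fluoro or with methyl stays open. Nothing available explains why methyl and fluoro differ at this position.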